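Working notes: hydroxy to hydrogen on compound 1

A few compounds are considered here, and "the series" means these few. Any claim that something is new, unique, unknown or untested is made for them only; others in the source may bear on it.

Values so far in a functional assay on MIA PaCa-2 cells (Homo sapiens) for antiproliferative activity, read by MTT assay, with a stated time of 72 h (a lower number here means a stronger inhibitor, a higher number a weaker inhibitor), are these:
- compound 1 `COc1cc(/C=C\c2cc3cc(O)ccc3s2)cc(OC)c1OC` gives "not determined" (no result reported)
- compound 2 `COc1csc(/C=C\c2cc(OC)c(OC)c(OC)c2)c1` gives 14 nM
- compound 3 `COc1ccc(/C=C\c2cc(OC)c(OC)c(OC)c2)s1` gives "not determined" (no result reported)

Compound 1 has no number to place it in the series. In this assay, for the measured compounds named here, it shares that position with compound 3, so compound 2 holds the only measured value. No comparison of compound 1 with either neighbour can be drawn from these results.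

The next compound to be read is compound 4 `COc1cc(/C=C\c2cc3ccccc3s2)cc(OC)c1OC`, which follows from compound 1 by one change: hydrogen in place of hydroxy on an aromatic carbon. In words, hydrogen stands in place of hydroxy on an aromatic carbon, and the rest of the structure is unchanged.

Going by the values given here, no measured step shows what this exchange does, and with no number for compound 1 the step has no measured starting point. The expectation is still a moderate step beyond the scatter in this assay toward a weaker inhibitor. Among the compounds with values here, the only numerical anchor is compound 2 at 14 nM and compound 4 is expected to fall on the weaker side of that value, with wide uncertainty.

In this assay compound 4 is estimated at 50 nM with an expected range from 6 nM to 400 nM in all.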

Compound 4, half-maximal inhibitory concentration: 7.8 nM
Beside the measured number, compound 4's estimate is 6.4-fold (0.81 log units) above it; measured number inside the range.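

In this assay compound 4 gives 7.8 nM while compound 1 gives "not determined" (no result reported) so no step can be read between compound 1 and compound 4. The compounds shown leave open what replacing hydroxy with hydrogen on the shared core does to activity. No evidence is available that bears on this result.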